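The source may report more compounds than this note shows. Statements on the series, on what has been measured and on what is new or still open speak of the compounds shown alone.

Measured so far in a functional assay on MT4 cells (Homo sapiens) for inhibition; on this read-out higher numbers stand for weaker inhibition and lower numbers for stronger inhibition:
Compound 1 `C/C(=C\COc1ccccc1)CC/C=C(\C)C1CC(=O)C(C)(C)O1`: 43.1 ug/mL
Compound 2 `C/C(=C\COc1c(Cl)cccc1Cl)CC/C=C(\C)C1=CC(=O)C(C)(C)O1`: 15.5 ug/mL

Compound 2 stands lowest of the two, at 15.5 ug/mL, and its gap to compound 1 lies beyond the scatter. Compound 3 `C/C(=C\COc1ccccc1)CC/C=C(\C)C1=CC(=O)C(C)(C)O1` has not yet been measured. It has phenyl in place of 2,6-dichlorophenyl on an oxygen on a saturated carbon. Going by the values given here, no step between measured compounds shows this change alone, so any forecast remains indirect. Compound 1, which also carries phenyl, gives 43.1 ug/mL, so a moderate rise in this assay is expected, towards weaker inhibition. The expected size is a 1.7-fold higher number from compound 2 to compound 3 (0.22 log units; within the scatter), and a result within the scatter would not be surprising. For compound 3 the estimated value is 26 ug/mL, with an expected range from 11 ug/mL to 60 ug/mL.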

Compound 3, half-maximal inhibitory concentration: 29.4 ug/mL
Beside the measured number, compound 3's estimate is 1.1-fold (0.05 log units) below it, and the stated range covers the measured number.
By their numbers in this assay, from the lowest: compounds 2, 3 and 1 (each within the scatter of the next, the first and the last beyond it).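

In this assay, phenyl in place of 2,6-dichlorophenyl on an oxygen on a saturated carbon gives a 1.9-fold higher number from compound 2 to compound 3 (0.28 log units; within the scatter) and so, in this one pair, does not separate the two groups at this position. The other single change, at the group with the five-membered non-aromatic ring on a double-bonded chain carbon, gives a 1.5-fold lower number from compound 1 to compound 3 (0.17 log units; within the scatter) and likewise stays inside what repeated measurements would show. Nothing among the data shown explains either step.

Going by these compounds, whether an amine or a carboxylic acid on the phenyl ring would move the number beyond the scatter remains open. So does the effect of a longer chain in place of phenyl on that oxygen.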